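The source may hold more compounds than are shown below. What is called first, only, known or untested is meant among the compounds shown, and "the series" means these compounds.

Compound 1 `COc1cc(-c2nc3ccccc3s2)ccc1OCC(=O)NNC(=O)CCl` stands at the lowest number of the three measured in a functional assay on MCF7 cells (Homo sapiens) for inhibition, read by MTT assay, with a stated time of 3 days (a higher number here means a weaker inhibitor, a lower number a stronger inhibitor), giving 780 nM. Compound 2 `COc1cc(-c2nc3ccccc3s2)ccc1OCC(=O)NNC(=O)CN(C(C)=O)[C@@H](CS)C(=O)O` gives 1750 nM in this assay, and compound 3 `CCOC(=O)CN(C)CC(=O)NNC(=O)COc1ccc(-c2nc3ccccc3s2)cc1OC` gives 1980 nM. Compound 4 `CCOC(=O)[C@H](CS)NCC(=O)NNC(=O)COc1ccc(-c2nc3ccccc3s2)cc1OC` differs from compound 1 in a single place: (1-(ethoxycarbonyl)-2-sulfanylethyl)amino in place of chloro on a saturated chain carbon bound to a carbonyl carbon. Among the measured compounds shown here, two measured steps bear on this change, since each also swaps the same chloro for a larger group at the same place: a 2.2-fold higher number from compound 1 to compound 2 (0.35 log units; beyond the scatter) and a 2.5-fold higher number from compound 1 to compound 3 (0.40 log units; beyond the scatter). Both were modest rises beyond the scatter, so a rise of similar size is expected for compound 4 in this assay. The expected step is a 2.3-fold higher number from compound 1 to compound 4 (0.36 log units; beyond the scatter). Compound 4 is therefore estimated at 1800 nM, within a range from 850 nM to 3800 nM.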

Compound 4, half-maximal inhibitory concentration: 2880 nM
Compound 4: middle estimate off by 1.6-fold (0.20 log units), on the low side; the range from low to high includes it.
By their numbers in this assay, from the lowest: compound 1; then compounds 2, 3 and 4 (each within the scatter of the next).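

In this assay, a third replacement of the chloro, this time by (1-(ethoxycarbonyl)-2-sulfanylethyl)amino, again gives a higher number (a 3.7-fold higher number from compound 1 to compound 4 (0.57 log units; beyond the scatter)), so compound 1 stays the strongest inhibitor of the four. The three replacements cannot be told apart, with a 1.5-fold higher number from compound 3 to compound 4 (0.16 log units; within the scatter) and a 1.6-fold higher number from compound 2 to compound 4 (0.22 log units; within the scatter). No measurement shown here explains the rise from the chloro. Still open, from the compounds shown here alone, is whether a bromo or a plain amino group at this place would keep the number of compound 1.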